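The source may hold more compounds than are shown below. What is called first, only, known or untested is meant among the compounds shown, and "the series" means these compounds.

Compound 1 `O=C(Nc1cc(C(F)(F)F)cc(C(F)(F)F)c1)c1cc(Cl)c(-c2ccccc2)cc1O` is the stronger of the two compounds measured in a functional assay on KG-1 cells (Homo sapiens) for cytotoxicity, read by luminescence and CellTiter-Glo, with a stated time of 3 days; on this read-out higher numbers stand for weaker inhibition and lower numbers for stronger inhibition: compound 1 gives 430 nM. Compound 2 `N#Cc1ccc(NC(=O)c2ccc(-c3cccnc3)cc2O)cc1` gives 7940 nM in this assay, a gap beyond the scatter, so compound 1 holds the lowest number here. Compound 3 `O=C(Nc1cc(C(F)(F)F)cc(C(F)(F)F)c1)c1ccc(-c2ccccc2)cc1O` differs from compound 1 by hydrogen in place of chloro on an aromatic carbon. Going by the values given here, no measured pair isolates this change, so the step is uncertain; a modest weakening is expected, a 2.1-fold higher number from compound 1 to compound 3 (0.32 log units; beyond the scatter) in this assay, not far beyond the scatter. Compound 3 is therefore estimated at 900 nM, with a range from 300 nM to 3000 nM.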

Compound 3, half-maximal inhibitory concentration: 860 nM
Compound 3: middle estimate off by 1.0-fold (0.02 log units), on the high side; low and high end bracket the measured number.
By their numbers in this assay, from the lowest: compounds 1 and 3 (each within the scatter of the next); then compound 2.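

In this assay, hydrogen in place of chloro on this aromatic carbon, ortho to a phenyl group and para to a hydroxy group, gives a 2.0-fold higher number from compound 1 to compound 3 (0.30 log units; within the scatter). This first direct pair therefore does not separate chloro from hydrogen at this position on this read-out. Nothing measured bears on why this is so.

From the compounds shown here alone, whether a bromo group, a methoxy group or an amine on this carbon would also stay within the scatter remains open. Going by these compounds, the step is also known only from this single pair, so its size on other members is unknown.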